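A few compounds are considered here, and "the series" means these few. Any claim that something is new, unique, unknown or untested is made for them only; others in the source may bear on it.

Compound 1 `COc1cccc(NC(=O)c2c(NO)cc(-c3ccccc3)oc2=O)c1`: in an ADME assay on Huh-7 cells (Homo sapiens) for cytotoxicity, with a stated time of 3 days (on this read-out lower numbers stand for higher toxicity in this test and higher numbers for lower toxicity in this test), compound 1 gives > 20000 nM, which is a limit of the test rather than a number.
Compound 2 `O=C(NC1CC1)c1c(NO)cc(-c2ccc(Cl)cc2)oc1=O`: in this assay compound 2 gives 12800 nM.
Compound 3 `O=C(Nc1ccccc1)c1c(NCCO)cc(-c2cccc(Br)c2)oc1=O`: in this assay compound 3 gives > 20000 nM, again a limit and not a number.

Compound 3 therefore stands at the edge of what this assay can report, and it shares that position with compound 1, as the limit of > 20000 nM in this assay, at which 2 of the 3 values shown sit, shows. Among the compounds with values here, no pair of the measured compounds differs in a single place, so no measured step is available to lean on.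

Compound 4 `COc1ccccc1NC(=O)c1c(NCCO)cc(-c2cccc(Br)c2)oc1=O` is the compound still to be measured. It is made from compound 3 by one change, (methoxy in place of hydrogen on an aromatic carbon). With compound 1 already carrying a methoxy on its anilide and sitting at the limit, this change is expected to leave the read-out essentially where compound 3 left it: the step from compound 3 to compound 4 is estimated as a step that the limit leaves unreadable from compound 3 to compound 4, no change beyond the usual scatter. Compound 4 is accordingly expected to give about 25000 nM, within a range of 8000 nM to 60000 nM, most likely reported again only as a limit.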

Compound 4, half-maximal cytotoxic concentration: > 20000 nM
Compound 4 was reported as a limit; the forecaster's own chance of this, stated with the estimate: 70%; the middle value lies beyond the limit too.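

Within the data shown here, compound 3 and compound 4 are both reported only as limits, so no step between them can be read: the limit of > 20000 nM in this assay, at which 3 of the 4 values shown sit. The compounds shown leave open whether methoxy in place of hydrogen on an aromatic carbon changes the read-out in this assay at all.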